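Phenyl for Difluorophenyl: A Step Expected Within Scatter

A few compounds are considered here, and "the series" means these few. Any claim that something is new, unique, unknown or untested is made for them only; others in the source may bear on it.

Compound 1 `C#CCN(CCCOc1ccc2ccc(=O)oc2c1)Cc1ccc(OC)cc1`: 60000 nM
Compound 2 `C#CCN(CCCOc1ccc2ccc(=O)oc2c1)Cc1ccc(F)c(F)c1`: 49200 nM

In an ADME assay on isolated protein for inhibition of Amine oxidase [flavin-containing] A (Homo sapiens), read by fluorescence and Amplex Red, with stated times of 15 min and 20 min (on this read-out higher numbers stand for weaker inhibition and lower numbers for stronger inhibition), compound 1 gives 60000 nM, while compound 2 gives 49200 nM. The step of a 1.2-fold lower number from compound 1 to compound 2 (0.09 log units; within the scatter) is within the scatter, so compound 2 stands level with compound 1 on these numbers. Compound 3 `C#CCN(CCCOc1ccc2ccc(=O)oc2c1)Cc1ccccc1` differs from compound 2 by phenyl in place of 3,4-difluorophenyl on a saturated chain carbon bound to an amine nitrogen. For the measured compounds named here, only that one measured step bears on this change, and it was small, so the expected step of a 1.1-fold higher number from compound 2 to compound 3 (0.05 log units; within the scatter) is none beyond the scatter. Compound 3 is therefore estimated at 55000 nM, in the expected range 25000 nM to 120000 nM.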

Compound 3, half-maximal inhibitory concentration: 38600 nM
For compound 3 the middle estimate is 1.4-fold (0.15 log units) above the measured one; measured number inside the range.
By their numbers in this assay, from the lowest: compounds 3, 2 and 1 (each within the scatter of the next).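

In this assay, taking away both fluorines gives a 1.3-fold lower number from compound 2 to compound 3 (0.11 log units; within the scatter), and taking away the methoxy gives a 1.6-fold lower number from compound 1 to compound 3 (0.19 log units; within the scatter). With the plain phenyl now in hand, neither 3,4-difluorophenyl nor the methoxy-bearing ring separates from it on a saturated chain carbon bound to an amine nitrogen. Nothing shown here explains these numbers. Still open, from the compounds shown here alone, is whether a carboxylic acid or an amine on this phenyl, or a naphthyl in its place, would give a step beyond the scatter.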